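Inverting the Chain Stereocentre in a Urea Series

This account rests on a few compounds, and the source may have more. Where it says the series, first, only, none or still open, it means among the compounds named here.

Measured so far:
Compound 1, `C[C@H](NC(=O)Nc1ccc(C(C)(C)C)cc1)c1ccccc1` — 100%
Compound 2, `CCCCCCc1ccc(NC(=O)N[C@H](C)c2ccccc2)cc1` — 100%

The two measured compounds were tested in an ADME assay on the whole organism with Oryza sativa as the target, tested at 0.1 uM; on this read-out lower numbers stand for a stronger effect and higher numbers for a weaker effect at the one concentration tested. Compound 1 gives 100%, and compound 2 gives 100%. On these numbers compound 2 stands level with compound 1 at the digits printed; the nearest measured neighbour is compound 1, and there is no change between them within the usual scatter.

The next compound, compound 3, `CCCCCCc1ccc(NC(=O)N[C@@H](C)c2ccccc2)cc1`, has not yet been measured in this assay. It differs from compound 2 as follows: the two compounds have the same atoms and bonds and differ only in configuration as drawn: 1 of 1 stereo elements differ; a stereocentre at a saturated chain carbon is drawn R in compound 2 and S in compound 3.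

For the measured compounds named here, no step between two measured compounds of this kind is available to guide an expectation. Since compound 2 already sits at the top of the scale in this assay with 100%, the step expected from compound 2 to compound 3 is no change at the digits printed from compound 2 to compound 3 (within the scatter), that is none beyond the scatter. Compound 3 is therefore estimated at 100%, with a range from 85% to 100%.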

Compound 3, a percentage reported as activity, at one concentration (the size of the read-out at that concentration, not a potency): 99%
Compound 3: middle estimate off by 1 percentage points, on the high side; measured number inside the range.
By their numbers in this assay, from the lowest: compounds 3, 1 and 2 (each within the scatter of the next).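

In this assay, inverting the chain stereocentre gives a number 1 percentage points lower from compound 2 to compound 3 (within the scatter), so this read-out does not separate the two configurations at this carbon, the only place in which the pair differs: the fact that compounds 2 and 3 differ only in the configuration as drawn

Placing hexyl instead of tert-butyl on the aromatic carbon, with the configuration as drawn unchanged, gives a number 1 percentage points lower from compound 1 to compound 3 (within the scatter), so this exchange also leaves no step beyond the scatter. Each change can now be read on its own, which the earlier pair could not show, since compound 1 and compound 2 differ in both places.

The compounds shown leave open whether the two configurations would separate at another concentration in this assay. They also leave open how a longer chain, an amine or a carboxylic acid in place of hexyl would read.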